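A few compounds are considered here, and "the series" means these few. Any claim that something is new, unique, unknown or untested is made for them only; others in the source may bear on it.

Measured compounds in a functional assay on A-375 cells (Homo sapiens) for antiproliferative activity, read by CCK-8 assay, with a stated time of 72 h, tested at 8 uM; a higher number here means a stronger effect of the compound at the concentration tested, a lower number a weaker effect:

compound 1 `Nc1ccccc1NC(=O)c1ccc(CSC(=S)N2CCN(Cc3ccccn3)CC2)cc1` gives 82.4%
compound 2 `CN(C(=S)SCc1ccc(C(=O)Nc2ccccc2N)cc1)c1cccnc1` gives 87.7%
compound 3 `COc1ccc(N2CCN(C(=S)SCc3ccc(C(=O)Nc4ccccc4N)cc3)CC2)cc1` gives 35.9%

Compound 2 stands highest of the three numbers, but its gap to compound 1 lies within the scatter, so the two cannot be ordered; compound 3 lies far below both. For the measured compounds named here, the one single-point step measured so far, a number 46.5 percentage points lower from compound 1 to compound 3 (beyond the scatter), sits on an amine nitrogen in a ring and shows that the group carried there can move the read-out a long way. Compound 4 `CCN(Cc1ccncc1)C(=S)SCc1ccc(C(=O)Nc2ccccc2N)cc1` is not yet measured. It differs from compound 2 by ethyl((pyridin-4-yl)methyl)amino in place of methyl(pyridin-3-yl)amino on a thiocarbonyl carbon. Going by the values given here, no measured step covers this exact change; the closest bearing comes from compound 1, which keeps a pyridinylmethyl group on its nitrogen and gives 82.4%, and from compound 2 itself. Both high readings carry a pyridine-bearing group on the nitrogen attached to the thiocarbonyl carbon, and compound 4 retains one, so no step beyond the scatter is expected; a modest lowering is allowed for by the wider range. Compound 4 is estimated at 80%, within 55% to 92%, which means an expected step of a number 7.7 percentage points lower from compound 2 to compound 4 (within the scatter).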

Compound 4, a percentage reported as inhibition, at one concentration (the size of the read-out at that concentration, not a potency): 86.2%
Compound 4: the middle estimate sits 6.2 percentage points below what was measured; measured number inside the range.
By their numbers in this assay, from the lowest: compound 3; then compounds 1, 4 and 2 (each within the scatter of the next).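

On the thiocarbonyl carbon, in this assay, ethyl((pyridin-4-yl)methyl)amino in place of methyl(pyridin-3-yl)amino gives a number 1.5 percentage points lower from compound 2 to compound 4 (within the scatter), so the read-out holds through an exchange that changes the alkyl group, the way the pyridine ring is attached and the heavy-atom count, while the donor and acceptor counts stay the same. For the compounds shown here, the earlier step, a number 46.5 percentage points lower from compound 1 to compound 3 (beyond the scatter), sits at a different place, an amine nitrogen in a ring, and showed only that a single change can move the read-out a long way; this step shows that a substantial change at the thiocarbonyl carbon need not do so. No supporting data bear on why the read-out holds through this exchange.

As far as these compounds go, both compounds were read at a single concentration, so any difference in potency between compound 2 and compound 4 stays open, since a percentage at one concentration does not give one. A morpholine or a plain benzyl group on the thiocarbonyl carbon would test whether a pyridine ring is needed at this position at all.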